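The compounds below may be only part of what the source reports. "The series", "measured", "known", "first", "only" and "open" are said of these compounds alone.

In a functional assay on CRL2813 cells (Homo sapiens) for cytotoxicity, read by sulforhodamine B assay, with a stated time of 5 days (a lower number here means a stronger inhibitor, a higher number a weaker inhibitor), compound 1 (`Cc1ccc(NC(=O)N[C@H]2CC[C@H](Oc3ccc(F)cc3)CC2)cc1`) gives > 20000 nM, which is a limit of the assay and not a number. Compound 2 (`O=C(Nc1ccccc1C(=O)O)N[C@H]1CC[C@@H](Oc2ccc(F)cc2)CC1`) gives > 20000 nM, which is also a limit. Compound 1 therefore has no exact value, and the data show only (the limit of > 20000 nM in this assay, at which 2 of the 2 values shown sit). Compound 3 (`O=C(Nc1ccccc1[N+](=O)[O-])N[C@H]1CC[C@H](Oc2ccc(F)cc2)CC1`) has 2-nitrophenyl in place of 4-methylphenyl on an amide-type nitrogen. For the measured compounds named here, no measured step between two compounds is available to gauge this change. The expectation is that compound 3 shows no change beyond the scatter in this assay, because compound 1 and compound 2 share (the limit of > 20000 nM in this assay, at which 2 of the 2 values shown sit). The expected change is a number no higher from compound 1 to compound 3 (the limit leaves the size open), which is estimated to remain small. For compound 3 the estimated value is 20000 nM, with an expected range from 7000 nM to 50000 nM.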

Compound 3, half-maximal inhibitory concentration: 3500 nM
Compound 3: the middle estimate sits 5.7-fold (0.76 log units) above what was measured, outside the stated range (below it).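

In this assay, the aryl group on the amide-type nitrogen proves to be a place where one change can move the read-out off the limit: 2-nitrophenyl in place of 4-methylphenyl gives an at least 5.7-fold lower number from compound 1 to compound 3 (0.75 log units; beyond the scatter). For the compounds shown here, compound 3 is the only compound here with an exact value, and the full size of the step stays unknown, as the value of compound 1 is a limit. The earlier compounds had shown only a shared limit: the limit of > 20000 nM in this assay, at which 2 of the 3 values shown sit.

The compounds shown leave open which feature of 2-nitrophenyl carries the step, as the nitro group arrives together with the loss of the methyl and with a different point of attachment on the ring. As far as these compounds go, whether an amine or a nitrile on that ring would also give an exact value remains open as well.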